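Hydroxy on the aryl imine of the pyrazolone series

The source may hold more compounds than are shown below. What is called first, only, known or untested is meant among the compounds shown, and "the series" means these compounds.

Compound 3 `Cc1c(/N=C/c2ccccc2)c(=O)n(-c2ccccc2)n1C` is the unsubstituted aryl imine of the shared core. Within the data shown here, in a functional assay on P388 cells (Mus musculus) for cytotoxicity, read by MTT assay, with a stated time of 72 h (a higher number here means a weaker inhibitor, a lower number a stronger inhibitor), compound 3 gives 240000000 nM, the second highest of the three numbers so far. Compound 1 `Cc1c(/N=C/c2ccc(N(C)C)cc2)c(=O)n(-c2ccccc2)n1C`, carrying dimethylamino on the aromatic carbon, gives 468000000 nM; compound 2 `COc1cccc(/C=N/c2c(C)n(C)n(-c3ccccc3)c2=O)c1`, carrying methoxy, gives 105000000 nM. The step of a 2.0-fold lower number from compound 1 to compound 3 (0.29 log units; within the scatter) lies within the scatter; the step of a 2.3-fold higher number from compound 2 to compound 3 (0.36 log units; beyond the scatter) is modest and beyond it.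

Compound 4 `Cc1c(/N=C/c2ccc(O)cc2)c(=O)n(-c2ccccc2)n1C` is not yet measured. The change from compound 3 is hydroxy in place of hydrogen on an aromatic carbon, sitting on an aromatic carbon of a six-membered aromatic ring of carbon only, para to a large group. Among the measured compounds shown here, the closest precedent is compound 1, where a substituent at the same kind of position gave only a within-scatter difference, a 2.0-fold lower number from compound 1 to compound 3 (0.29 log units; within the scatter). Compound 2 shows that a small oxygen substituent on the ring can lower the number modestly, a 2.3-fold higher number from compound 2 to compound 3 (0.36 log units; beyond the scatter), but at a different place. Taken together, no step beyond the scatter is expected in this assay; the estimated step of a 1.2-fold lower number from compound 3 to compound 4 (0.08 log units; within the scatter) is small. For compound 4 the number expected is 200000000 nM, with a range from 80000000 nM to 500000000 nM.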

Compound 4, half-maximal inhibitory concentration: 537000000 nM
The estimate for compound 4 lay 2.7-fold (0.43 log units) below the measured number; the whole stated range lies below it.
By their numbers in this assay, from the lowest: compound 2; then compounds 3, 1 and 4 (each within the scatter of the next, the first and the last beyond it).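

In this assay, among these compounds, hydroxy on an aromatic carbon para to a large group gives the first step at this kind of position that passes the scatter (a 2.2-fold higher number from compound 3 to compound 4 (0.35 log units; beyond the scatter)), and it goes towards a higher number, whereas dimethylamino at this kind of position stayed within the scatter of the unsubstituted compound 3. Hydroxy and dimethylamino cannot be told apart here (a 1.1-fold higher number from compound 1 to compound 4 (0.06 log units; within the scatter)), so both substituents at this place end up at the high end of the series, while the largest step so far (a 5.1-fold higher number from compound 2 to compound 4 (0.71 log units; beyond the scatter)) shows how far the ring substituent alone can spread the numbers. Nothing shown gives a reason for the rise with hydroxy.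

Still open, from the compounds shown here alone, is whether the rise belongs to hydroxy itself or would follow any substituent on this aromatic carbon; a fluorine or a carboxylic acid at the same place would test that. The largest step also changes both the group and its place on the ring, so the contribution of each stays unresolved until methoxy is read on this same carbon.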